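From Methoxy to Trifluoromethyl in a Small Series

The source may hold more compounds than are shown below. What is called first, only, known or untested is meant among the compounds shown, and "the series" means these compounds.

- compound 1 `O=C(Nc1ccccc1)C1CCN(C/C=C/c2ccccc2)CC1` gives 69700 nM 
- compound 2 `CCc1ccc(NC(=O)C2CCN(C/C=C/c3ccccc3)CC2)cc1` gives 19600 nM 
- compound 3 `COc1cccc(NC(=O)C2CCN(C/C=C/c3ccccc3)CC2)c1` gives 50500 nM 

All three values come from a functional assay on A549 cells (Homo sapiens) for inhibition, read by MTT assay, with a stated time of 72 h (on this read-out higher numbers stand for weaker inhibition and lower numbers for stronger inhibition), and all three compounds share one core. Compound 3 cannot be told apart from compound 1, given a 1.4-fold lower number from compound 1 to compound 3 (0.14 log units; within the scatter) as the step between them. It lies clearly above compound 2, given a 2.6-fold higher number from compound 2 to compound 3 (0.41 log units; beyond the scatter) as the step.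

Compound 4 `O=C(Nc1cccc(C(F)(F)F)c1)C1CCN(C/C=C/c2ccccc2)CC1` changes one group of compound 3, with trifluoromethyl in place of methoxy on an aromatic carbon, meta to a large group trifluoromethyl in place of methoxy on an aromatic carbon and the rest unchanged. Among the compounds with values here, no measured step makes this exact swap, and no measured compound carries trifluoromethyl. The nearest guides are compound 3, with a 1.4-fold lower number from compound 1 to compound 3 (0.14 log units; within the scatter) on adding methoxy, and compound 2, with a 3.6-fold lower number from compound 1 to compound 2 (0.55 log units; beyond the scatter) on adding ethyl. Both steps are small, so no step beyond the scatter is expected in this assay and any shift should lean slightly lower. The expected step is a 1.4-fold lower number from compound 3 to compound 4 (0.16 log units; within the scatter) by this estimate. For compound 4 the estimated value is 35000 nM with an expected range from 14000 nM to 80000 nM in repeated measurements.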

Compound 4, half-maximal inhibitory concentration: 15600 nM
The estimate for compound 4 lay 2.2-fold (0.35 log units) above the measured number; measured number inside the range.
By their numbers in this assay, from the lowest: compounds 4 and 2 (each within the scatter of the next); then compounds 3 and 1 (each within the scatter of the next).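

In this assay, this place on the aromatic ring proves sensitive to which group sits there: the swap of methoxy for trifluoromethyl gives a 3.2-fold lower number from compound 3 to compound 4 (0.51 log units; beyond the scatter) and so stronger inhibition. Measured against plain hydrogen, trifluoromethyl gives a 4.5-fold lower number from compound 1 to compound 4 (0.65 log units; beyond the scatter) while methoxy gives only a 1.4-fold lower number from compound 1 to compound 3 (0.14 log units; within the scatter), so at this place one group moves the number clearly and the other does not. Nothing measured here explains the difference between the two groups.

Trifluoromethyl appears at this one place only, so what it would do elsewhere on the ring stays open. Also open, from the compounds shown here alone, is how other groups would behave at this place, such as a nitrile, a chlorine atom or an amine.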